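A few compounds are considered here, and "the series" means these few. Any claim that something is new, unique, unknown or untested is made for them only; others in the source may bear on it.

Measured so far in an ADME assay on HEL cells (Homo sapiens) for cytotoxicity, with a stated time of 3 days; on this read-out higher numbers stand for lower toxicity in this test and lower numbers for higher toxicity in this test:
Compound 1, `CCC1(Cc2ccccc2)OS(=O)(=O)C=C1OCC(=O)OC`: compound 1 gives > 400000 nM, which is a limit of the assay.
Compound 2, `CCC1(Cc2ccccc2)OS(=O)(=O)C=C1OCC#N`: compound 2 gives > 400000 nM, also a limit.
Compound 3, `CCC1(Cc2ccccc2)OS(=O)(=O)C=C1OCc1ccc(F)cc1`: compound 3 gives >= 50000 nM, again a limit.

Compound 3 therefore stands nowhere definite on the numbers shown: its value is only a limit, and the two further values are limits as well. The steps that lead to it, a step that the two limits leave unreadable from compound 1 to compound 3 and a step that the two limits leave unreadable from compound 2 to compound 3, are both unreadable in size, as is a step that the two limits leave unreadable from compound 1 to compound 2. The evidence behind this is the limit of > 400000 nM in this assay, at which 2 of the 3 values shown sit, and (the limit of >= 50000 nM in this assay, at which 1 of the 3 values shown sits).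

Compound 4 is `CCC1(Cc2ccccc2)OS(=O)(=O)C=C1OCc1ccccc1Cl`. It differs from compound 3 at the saturated chain carbon bound to an oxygen on an unsaturated carbon: 2-chlorophenyl in place of 4-fluorophenyl on a saturated chain carbon bound to an oxygen on an unsaturated carbon.

Among the measured compounds shown here, no measured step bears readably on this change, so no size of step in this assay can be expected in either direction beyond the scatter. Compound 4 is estimated at 150000 nM, most likely again reported as a limit. The expected range runs from 50000 nM to 400000 nM. The step that this estimate implies is a step that the limit leaves unreadable from compound 3 to compound 4, and it is expected to be unreadable in the same way as the steps among compounds 1, 2 and 3.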

Compound 4, minimum cytotoxic concentration: >= 20000 nM
Compound 4: only a limit was reported; the forecaster's own chance of this, stated with the estimate: 85%; the middle value does not contradict the limit.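

The result for compound 4 is only a limit, so none of its steps to compound 1, compound 2 or compound 3 can be read in this assay: the limit of >= 20000 nM in this assay, at which 1 of the 4 values shown sits.

The compounds shown leave open where any of the four actually stands, and whether the group on the saturated chain carbon bound to an oxygen on an unsaturated carbon changes the read-out at all.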